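Swapping a Carboxylic Acid Chain for Isopropyl on the Amine

This account rests on a few compounds, and the source may have more. Where it says the series, first, only, none or still open, it means among the compounds named here.

Compound 1, `NC(=O)c1cccc(CN(CCCC(=O)O)C[C@H]2O[C@@H](n3cnc4c(N)ncnc43)[C@H](O)[C@@H]2O)c1`, gives > 250000 nM in an assay on cells for inhibition of Nicotinamide N-methyltransferase (Homo sapiens), with stated times of 10 min and 30 min (a lower number here means a stronger inhibitor, a higher number a weaker inhibitor), which is a limit of the assay rather than a number.
Compound 2, `COC(=O)c1cccc(CN(CCCC(N)=O)C[C@H]2O[C@@H](n3cnc4c(N)ncnc43)[C@H](O)[C@@H]2O)c1`, gives > 250000 nM in this assay, again a limit.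
Compound 3, `COC(=O)c1cccc(CN(CCCC(=O)O)C[C@H]2O[C@@H](n3cnc4c(N)ncnc43)[C@H](O)[C@@H]2O)c1`, gives > 250000 nM in this assay, also a limit.

Compound 3 therefore stands only at a boundary of what this assay can report: all three values shown sit at the limit of > 250000 nM in this assay, at which 3 of the 3 values shown sit, so none of them is a measured number. Among the compounds with values here, the two steps that lead to compound 3, a step that the two limits leave unreadable from compound 1 to compound 3 and a step that the two limits leave unreadable from compound 2 to compound 3, are consequently unreadable in size and direction; they tell only that exchanging the groups on the carbonyl carbon left every compound beyond the limit.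

Compound 4, `COC(=O)c1cccc(CN(C[C@H]2O[C@@H](n3cnc4c(N)ncnc43)[C@H](O)[C@@H]2O)C(C)C)c1`, differs from compound 3 by isopropyl in place of 3-carboxypropyl on an amine nitrogen. No measured step touches the amine nitrogen, so nothing shown gives a size or direction for this change. Compound 4 is expected to give 50000 nM, with a range from 5000 nM to 250000 nM. The step from compound 3 to compound 4 is thus estimated at an at least 5.0-fold lower number from compound 3 to compound 4 (0.69 log units; beyond the scatter), with real uncertainty about whether a number will be read at all.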

Compound 4, half-maximal inhibitory concentration: > 250000 nM
Compound 4 was reported as a limit; the forecaster's own chance of this, stated with the estimate: 40%; at least 5.0-fold (0.69 log units) between middle value and limit.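

The steps from compound 3 and from compound 2 to compound 4 cannot be read, because compound 4 also stops at a limit: the limit of > 250000 nM in this assay, at which 4 of the 4 values shown sit.

The compounds shown leave open whether changing the group on the amine nitrogen or the carbonyl carbon shifts the number in this assay at all, and in which direction.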